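The source may report more compounds than this note shows. Statements on the series, on what has been measured and on what is new or still open speak of the compounds shown alone.

The series in a functional assay on K562 cells (Homo sapiens) for antiproliferative activity, read by MTT assay, with a stated time of 72 h (on this read-out lower numbers stand for stronger inhibition and higher numbers for weaker inhibition), starts from compound 2 `O=C(/C=C/c1ccc(/C=C/C(=O)c2ccccc2)cc1)NO`, which gives 2280 nM. Compound 1 `CN1CCN(c2ccccc2C(=O)/C=C/c2ccc(/C=C/C(=O)NO)cc2)CC1` carries the change 4-methylpiperazin-1-yl in place of hydrogen on an aromatic carbon and gives 1600 nM; the step of a 1.4-fold lower number from compound 2 to compound 1 (0.15 log units; within the scatter) is within the scatter. Compound 3 `O=C(/C=C/c1ccc(/C=C/C(=O)c2ccccc2)cn1)NO` differs from compound 2 in its core, and the difference between the two cores is not broken down here; in this assay compound 3 gives 690 nM, the lowest of the three numbers, beyond the scatter from both compound 1 and compound 2.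

Compound 4 `CN1CCN(c2ccc(C(=O)/C=C/c3ccc(/C=C/C(=O)NO)nc3)cc2)CC1` is obtained from compound 3 by 4-methylpiperazin-1-yl in place of hydrogen on an aromatic carbon. This is the same kind of change as that from compound 2 to compound 1, but not the same: in compound 1 the entering group sits ortho to a large group, whereas in compound 4 it sits para to a large group, and the core is that of compound 3.

Because the earlier step of a 1.4-fold lower number from compound 2 to compound 1 (0.15 log units; within the scatter) was within the scatter, compound 4 is expected to show a step of about a 1.4-fold lower number from compound 3 to compound 4 (0.14 log units; within the scatter). Compound 4 is therefore estimated at 500 nM, within a range of 250 nM to 1200 nM.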

Compound 4, half-maximal inhibitory concentration: 410 nM
Beside the measured number, compound 4's estimate is 1.2-fold (0.09 log units) above it; measured number inside the range.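

In this assay, 4-methylpiperazin-1-yl in place of hydrogen gives a 1.7-fold lower number from compound 3 to compound 4 (0.23 log units; within the scatter), and this step agrees with the one seen on the other core: the same change on two cores in this assay, a 1.4-fold lower number (0.15 log units; within the scatter) from compound 2 to compound 1 and a 1.7-fold lower number (0.23 log units; within the scatter) from compound 3 to compound 4, 1.2-fold (0.07 log units) apart, within the scatter of two such steps

The change therefore carries across these two cores in the sense that neither step lies beyond the scatter, so neither can be told apart from no effect of the group on this read-out. This does not show that the group is without effect in general or that the result would hold on other cores, and since the entering group sits para to a large group in compound 4 but elsewhere in compound 1, the two steps differ in place as well as in core.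

The compounds shown leave open whether a different place on one and the same core would change the size of the step. They also leave open whether a dimethylamino group or a carboxylic acid in place of 4-methylpiperazin-1-yl would give a step beyond the scatter.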